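The compounds below may be only part of what the source reports. "The series", "measured", "known", "first", "only" and "open" are said of these compounds alone.

Measured compounds:
- compound 1 `O=C(Nc1cc2c(OCCC3CCCCN3)c(-c3ccc(Cl)c(Cl)c3)c(O)nc2cc1Cl)NC1CC1` gives 18 nM
- compound 2 `Cc1cc(-c2c(O)nc3cc(Cl)c([N+](=O)[O-])cc3c2OCCC2CCCCN2)cc(C(C)O)c1` gives 63 nM
- compound 3 `Cc1cc(C)cc(-c2c(O)nc3cc(Cl)c(NC(=O)c4cnccn4)cc3c2OCCC2CCCCN2)c1` gives 1.8 nM

These three compounds share a core and were tested in a functional assay on cells (Pituitary gland cell) for antagonist activity at Gonadotropin-releasing hormone receptor (Rattus norvegicus); a higher number here means a weaker inhibitor, a lower number a stronger inhibitor. Among them compound 2 stands highest of the three numbers. Its nearest neighbour is compound 1, which sits lower by a margin beyond the scatter, and its furthest is compound 3, which lies far lower, again beyond the scatter. No pair of these compounds differs in just one place, so no single step has been measured.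

Compound 4 `O=[N+]([O-])c1cc2c(OCCC3CCCCN3)c(-c3ccccc3Cl)c(O)nc2cc1Cl` has not yet been tested in this assay. It differs from compound 2 in one place: 2-chlorophenyl in place of 3-(1-hydroxyethyl)-5-methylphenyl on an aromatic carbon. Going by the values given here, no comparable step is on record. The direction of this change can only be guessed from compound 2 with its value of 63 nM. The change is expected to move the number little, perhaps somewhat upward, and the step from compound 2 to compound 4 is estimated at a 1.6-fold higher number from compound 2 to compound 4 (0.20 log units; within the scatter). Compound 4 is therefore expected to give about 100 nM, within a range of 25 nM to 400 nM.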

Compound 4, half-maximal inhibitory concentration: 360 nM
Beside the measured number, compound 4's estimate is 3.6-fold (0.56 log units) below it; low and high end bracket the measured number.
By their numbers in this assay, from the lowest: compound 3; then compound 1; then compound 2; then compound 4.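

In this assay, replacing 3-(1-hydroxyethyl)-5-methylphenyl with 2-chlorophenyl on the aromatic carbon ortho to a hydroxy group gives a 5.7-fold higher number from compound 2 to compound 4 (0.76 log units; beyond the scatter), so this exchange weakens inhibition by a margin beyond the scatter. Going by these compounds alone, this is the first single-place comparison, and it shows that the group at this position affects the number while the rest of the molecule stays the same. No measurement on hand explains the change.

The exchange alters the substituents and their placement on the phenyl ring together, including the loss of the hydroxyethyl group, so the contribution of each remains unresolved. The compounds shown also leave open how unsubstituted phenyl, or phenyl carrying a single 1-hydroxyethyl group, would behave at this position.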